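From a Fluorophenyl to a Dichlorobenzyl Triazole

The compounds below may be only part of what the source reports. "The series", "measured", "known", "first", "only" and "open" are said of these compounds alone.

Compound 1 `CC(C)(C)OC(=O)N1CCN(C(=S)SCc2cn(-c3ccccc3F)nn2)CC1` reaches only the limit in a functional assay on ECa-109 cells (Homo sapiens) for inhibition, read by MTT assay, with a stated time of 72 h (on this read-out higher numbers stand for weaker inhibition and lower numbers for stronger inhibition), giving > 128000 nM. Compound 2 `O=C(OCc1ccccc1)N1CCN(C(=S)SCc2cn(Cc3ccc(Cl)cc3)nn2)CC1` likewise reaches the limit, with > 128000 nM. Compound 3 `O=C(OCc1ccccc1)N1CCN(C(=S)SCc2cn(Cc3ccccc3F)nn2)CC1` gives 27000 nM in this assay. For the measured compounds named here, the single measured step, an at least 4.7-fold lower number from compound 2 to compound 3 (0.67 log units; beyond the scatter), runs from a chlorinated benzyl toward a fluorinated one, and its true size is open because of the limit of > 128000 nM in this assay, at which 2 of the 3 values shown sit. Compound 4 `CC(C)(C)OC(=O)N1CCN(C(=S)SCc2cn(Cc3ccc(Cl)c(Cl)c3)nn2)CC1` arises from compound 1 by 3,4-dichlorobenzyl in place of 2-fluorophenyl on an aromatic nitrogen. Going by the values given here, no measured step sets a dichlorobenzyl against a fluorophenyl; the nearest hint is that compound 2, carrying a chlorinated benzyl, sits at the limit. Compound 4 is therefore expected to remain weak, with the step of an at least 1.2-fold lower number from compound 1 to compound 4 (0.10 log units; that floor lies within the scatter) likely small. The estimate for compound 4 in this assay is 100000 nM, within 30000 nM to 250000 nM.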

Compound 4, half-maximal inhibitory concentration: > 128000 nM
Compound 4: only a limit was reported; the forecaster's own chance of this, stated with the estimate: 55%; middle value at least 1.2-fold (0.10 log units) from the limit.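

In this assay compound 4 gives > 128000 nM, which is a limit. Compound 1 gives > 128000 nM, also a limit, so no step between these two compounds can be read: the limit of > 128000 nM in this assay, at which 3 of the 4 values shown sit.

The compounds shown leave open how strongly compound 1 and compound 4 actually inhibit, and whether 3,4-dichlorobenzyl differs from 2-fluorophenyl at all.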